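Swapping hydroxymethyl for carboxy in a chloroacetamide

The source may hold more compounds than are shown below. What is called first, only, known or untested is meant among the compounds shown, and "the series" means these compounds.

Compound 1 `C=CC(=O)Nc1ccc(Cn2nc(-c3ccc(Oc4ccccc4)cc3)cc2C(=O)O)cc1` gives > 60000 nM as a limit
Compound 2 `O=C(CCl)Nc1cccc(Cn2nc(-c3ccc(Oc4ccccc4)cc3)cc2CO)c1` gives 400 nM as a measured number

Within the data shown here, in a functional assay on Rec1 cells (Homo sapiens) for inhibition, read by luminescence and CellTiter-Glo, with a stated time of 72 h (on this read-out higher numbers stand for weaker inhibition and lower numbers for stronger inhibition), compound 2 gives 400 nM as the only actual number so far. Compound 1, which bears carboxy, stands at > 60000 nM and this is a limit, not a number. Compound 3 `O=C(CCl)Nc1cccc(Cn2nc(-c3ccc(Oc4ccccc4)cc3)cc2C(=O)O)c1` has carboxy in place of hydroxymethyl on an aromatic carbon and is not yet measured. Weaker inhibition, beyond the usual scatter, is expected in this assay on the strength of that limit. The expected size is a 10-fold higher number from compound 2 to compound 3 (1.00 log units; beyond the scatter) as estimated here. For compound 3 the estimated value is 4000 nM with an expected range from 600 nM to 40000 nM in this assessment.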

Compound 3, half-maximal inhibitory concentration: 7100 nM
Compound 3: the middle estimate sits 1.8-fold (0.25 log units) below what was measured, within the range that was stated.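

In this assay, carboxy in place of hydroxymethyl on this aromatic carbon gives an 18-fold higher number from compound 2 to compound 3 (1.25 log units; beyond the scatter): the change costs a large step, yet compound 3 still gives a measured number. With carboxy held in place, 3-(((chloromethyl)carbonyl)amino)phenyl in place of 4-((vinylcarbonyl)amino)phenyl gives an at least 8.4-fold lower number from compound 1 to compound 3 (0.92 log units; beyond the scatter), a step whose full size stays unknown, as it starts from a limit: the limit of > 60000 nM in this assay, at which 1 of the 3 values shown sits.

As far as these compounds go, whether a methyl ester or a primary amide on this aromatic carbon would track hydroxymethyl or carboxy remains open. So does how 3-((vinylcarbonyl)amino)phenyl would compare with the groups shown.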